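Replacing chloro on the aromatic carbon of compound 1

The source may hold more compounds than are shown below. What is called first, only, known or untested is meant among the compounds shown, and "the series" means these compounds.

Measured compounds:
- compound 1, `CCc1nc2c(C)cc(C)nc2n1Cc1ccc(OC(C(=O)O)c2ccccc2)c(Cl)c1`: 720 nM
- compound 2, `CCCCc1cc(Cn2c(CC)nc3c(C)cc(C)nc32)ccc1OC(C(=O)O)c1ccccc1`: 140 nM

In an assay on Midbrain with Type-2 angiotensin II receptor (Rattus norvegicus) as the target (on this read-out higher numbers stand for weaker inhibition and lower numbers for stronger inhibition), compound 1 gives 720 nM, the highest of the two numbers; the nearest is compound 2, which in this assay gives 140 nM. For the measured compounds named here, the one step already measured between these two, a 5.1-fold lower number from compound 1 to compound 2 (0.71 log units; beyond the scatter), is the only one that bears on the change considered here, since it alters the same aromatic carbon of the shared core.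

Compound 3, `CCc1nc2c(C)cc(C)nc2n1Cc1ccc(OC(C(=O)O)c2ccccc2)c(C(=O)c2ccccc2)c1`, differs from compound 1 as follows: benzoyl in place of chloro on an aromatic carbon. Benzoyl, like butyl in compound 2, brings a larger group to the position that carries chloro in compound 1, and benzoyl adds one hydrogen-bond acceptor that butyl does not. Because the step of a 5.1-fold lower number from compound 1 to compound 2 (0.71 log units; beyond the scatter) was modest but beyond the scatter, a lower number in this assay is expected for compound 3 as well, of roughly comparable size, though with wider uncertainty since benzoyl differs from butyl in shape and in the carbonyl it carries. The expected step from compound 1 is a 3.3-fold lower number from compound 1 to compound 3 (0.51 log units; beyond the scatter). For compound 3 the estimate in this assay is 220 nM, with a range from 60 nM to 800 nM.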

Compound 3, half-maximal inhibitory concentration: 60 nM
Estimate against measurement, compound 3: 3.7-fold (0.56 log units) above; the measured number falls inside the stated range.
By their numbers in this assay, from the lowest: compound 3; then compound 2; then compound 1.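

In this assay, the aromatic carbon that carries chloro in compound 1 accepts a much bulkier substituent than butyl, and benzoyl in place of chloro gives a 12-fold lower number from compound 1 to compound 3 (1.08 log units; beyond the scatter) with the step rated large. The two larger groups are also not interchangeable here: benzoyl in place of butyl gives a 2.3-fold lower number from compound 2 to compound 3 (0.37 log units; beyond the scatter) and so places compound 3 lowest of the three, which shows that the result at this carbon depends on which group enters and not only on chloro leaving. Nothing available indicates what lies behind these steps.

The compounds shown do not separate the contribution of the carbonyl in benzoyl from that of its aromatic ring, a question that acetyl, which keeps the carbonyl without the ring, and benzyl, which keeps the ring without the carbonyl, would address. Also open, on these data alone, is how far the trend extends at this carbon, for instance to a substituted benzoyl, a longer chain than butyl, or an amine.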